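The source may report more compounds than this note shows. Statements on the series, on what has been measured and on what is new or still open speak of the compounds shown alone.

For the measured compounds named here, in an ADME assay (Rattus norvegicus) for inhibition (a higher number here means a weaker inhibitor, a lower number a stronger inhibitor), compound 3 `CCOc1ccc(NC2=CC(=O)c3nc(-c4ccccn4)[nH]c3C2=O)cc1` gives 6500 nM, the lowest of the three numbers measured so far. Compound 1 `O=C1C=C(Nc2ccc(Br)cc2)C(=O)c2[nH]c(-c3ccccn3)nc21` gives 12000 nM, and a 1.8-fold lower number from compound 1 to compound 3 (0.27 log units; within the scatter). Compound 2 `O=C1C=C(Nc2ccc(I)cc2)C(=O)c2[nH]c(-c3ccccn3)nc21` gives 20000 nM; a 3.1-fold lower number from compound 2 to compound 3 (0.49 log units; beyond the scatter), while a 1.7-fold higher number from compound 1 to compound 2 (0.22 log units; within the scatter). Compound 4 `O=C1C=C(Nc2ccc(OC(F)(F)F)cc2)C(=O)c2[nH]c(-c3ccccn3)nc21` is reached from compound 3 by a single change: trifluoromethyl in place of ethyl on an oxygen on an aromatic ring. Going by the values given here, none of the measured steps alters the group on this oxygen; each of them exchanges what sits on the aromatic carbon, and even the largest of those was only modest. A step of at most similar size is therefore expected for compound 4, with no clear direction. The expected step is a 1.2-fold higher number from compound 3 to compound 4 (0.06 log units; within the scatter). Compound 4 is estimated to give about 7500 nM, within 3000 nM to 18000 nM.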

Compound 4, half-maximal inhibitory concentration: 20000 nM
The estimate for compound 4 lay 2.7-fold (0.43 log units) below the measured number; measured number outside the range, above it.
By their numbers in this assay, from the lowest: compounds 3, 1, 2 and 4 (each within the scatter of the next, the first and the last beyond it).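

In this assay, for the compounds shown here, the group on this oxygen does count: trifluoromethyl in place of ethyl gives a 3.1-fold higher number from compound 3 to compound 4 (0.49 log units; beyond the scatter) as the first measured change at this atom. Trifluoromethoxy cannot be told apart from iodo or bromo on the aromatic carbon, with no change at the digits printed from compound 2 to compound 4 (within the scatter) and a 1.7-fold higher number from compound 1 to compound 4 (0.22 log units; within the scatter) as the steps. Nothing measured here explains why the ethoxy compound differs from the trifluoromethoxy compound. Still open, as far as these compounds go, is how a longer chain on this oxygen would behave, or an amine or a carboxylic acid on the aromatic carbon.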